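The source may hold more compounds than are shown below. What is called first, only, known or untested is meant among the compounds shown, and "the series" means these compounds.

Of the compounds shown here, three sharing one core have been measured in a functional assay on CRL2813 cells (Homo sapiens) for cytotoxicity, read by sulforhodamine B assay, with a stated time of 5 days; on this read-out lower numbers stand for stronger inhibition and higher numbers for weaker inhibition. Compound 1 `Cc1ccc(NC(=O)N[C@H]2CC[C@H](Oc3ccc(F)cc3)CC2)cc1` reaches only a limit of this assay, > 20000 nM. Compound 2 `CSc1ccc(NC(=O)N[C@H]2CC[C@H](Oc3ccc(F)cc3)CC2)cc1` likewise stops at a limit in this assay, > 20000 nM. Among the compounds with values here, compound 3 `O=C(Nc1ccccc1Br)N[C@H]1CC[C@H](Oc2ccc(F)cc2)CC1` is the one compound with a number in this assay, 7700 nM, and so it stands alone as the only read value among the three. The step from compound 1 to compound 2, methylsulfanyl in place of methyl on an aromatic carbon, is a step that the two limits leave unreadable from compound 1 to compound 2 because of the limit of > 20000 nM in this assay, at which 2 of the 3 values shown sit. The two steps that lead into compound 3 are readable: an at least 2.5-fold lower number from compound 1 to compound 3 (0.41 log units; beyond the scatter) and an at least 2.5-fold lower number from compound 2 to compound 3 (0.41 log units; beyond the scatter). Both show that exchanging the group on the amide-type nitrogen has moved the read-out by at least a modest amount.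

Compound 4 `O=C(Nc1cccc(C(=O)O)c1)N[C@H]1CC[C@H](Oc2ccc(F)cc2)CC1` has not yet been measured. Its change from compound 3 is 3-carboxyphenyl in place of 2-bromophenyl on an amide-type nitrogen. Within the data shown here, no measured step carries a 3-carboxyphenyl, and both readable steps run toward compound 3 rather than away from it, so the direction of this new exchange is uncertain. Compound 4 is expected to drift back toward the limit, with an estimated 1.9-fold higher number from compound 3 to compound 4 (0.29 log units; within the scatter). Compound 4 is therefore estimated at 15000 nM, in a range from 4000 nM to 60000 nM.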

Compound 4, half-maximal inhibitory concentration: > 20000 nM
Compound 4: only a limit was reported; the forecaster's own chance of this, stated with the estimate: 55%; middle value at least 1.3-fold (0.12 log units) from the limit.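

Exchanging 2-bromophenyl for 3-carboxyphenyl on the amide-type nitrogen gives an at least 2.5-fold higher number from compound 3 to compound 4 (0.41 log units; beyond the scatter) in this assay, so the read-out at this position moves away from compound 3 as well as toward it. Compound 4 thus joins compound 1 and compound 2 at the assay limit, and 2-bromophenyl in compound 3 is the only group shown at this position that gives a read number. The steps from compound 1 and from compound 2 to compound 4 cannot be read, and 4-methylphenyl, 4-(methylsulfanyl)phenyl and 3-carboxyphenyl cannot be ranked against one another: the limit of > 20000 nM in this assay, at which 3 of the 4 values shown sit.

The compounds shown leave open whether the rise follows from the bromine leaving, from the carboxylic acid entering, or from the different place of the group on the phenyl ring. Going by these compounds, how an unsubstituted phenyl, or a phenyl carrying an amine or a nitrile, would read also remains open, as does whether any group at this position can improve on compound 3, which gives 7700 nM.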